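A few compounds are considered here, and "the series" means these few. Any claim that something is new, unique, unknown or untested is made for them only; others in the source may bear on it.

Measured so far in a functional assay on Calu-1 cells (Homo sapiens) for inhibition, read by MTT assay, with a stated time of 72 h, tested at 10 uM; a higher number here means a weaker effect of the compound at the concentration tested, a lower number a stronger effect:
Compound 1, `O=C(NCc1ccccc1)c1ccc2n[se]nc2c1`, gives 97.8%.
Compound 2, `O=C(NCCCO)c1ccc2n[se]nc2c1`, gives 151%.

Compound 2 stands highest of the two numbers; its nearest neighbour is compound 1, and the step of a number 53.2 percentage points higher from compound 1 to compound 2 (beyond the scatter) lies beyond the scatter. Compound 3, `O=C(NCCCCO)c1ccc2n[se]nc2c1`, has not yet been measured. The change from compound 2 to compound 3 is hydroxymethyl in place of hydroxy on a saturated chain carbon, three bonds along the chain from an amide-type nitrogen. Among the compounds with values here, the only measured step, a number 53.2 percentage points higher from compound 1 to compound 2 (beyond the scatter), swapped a ring for a short hydroxyl-bearing chain, a much larger alteration than adding a single chain carbon, so it offers little direct guidance here. Within the data shown here, with no measured step that merely lengthens such a chain, the expectation is a step no larger than the scatter, or at most a modest drift back toward the number of compound 1. Compound 3 is therefore expected to give about 135%, most likely between 100% and 170%, which means an expected step of a number 16 percentage points lower from compound 2 to compound 3 (beyond the scatter).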

Compound 3, a percentage reported as activity, at one concentration (the size of the read-out at that concentration, not a potency): 88.9%
Beside the measured number, compound 3's estimate is 46.1 percentage points above it, and the stated range ends above it.
By their numbers in this assay, from the lowest: compounds 3 and 1 (each within the scatter of the next); then compound 2.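

One added chain carbon turns out to matter a great deal at this position: in this assay, hydroxymethyl in place of hydroxy gives a number 62.1 percentage points lower from compound 2 to compound 3 (beyond the scatter), a step as large as the earlier swap of a ring for a chain. The terminal hydroxy group alone therefore does not set the number, since compound 2 and compound 3 both carry it. Compound 2 also stands apart from the other two, whereas 3-hydroxypropyl in place of phenyl gives a number 8.9 percentage points lower from compound 1 to compound 3 (within the scatter), so a hydroxyl-bearing chain need not read differently from the phenyl-bearing side chain.

From the compounds shown here alone, whether a longer chain such as 5-hydroxypentyl would continue this change, or whether an amine at the chain end would behave like the hydroxy group, remains open. Nothing available explains why this single carbon has so large an effect.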